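This account rests on a few compounds, and the source may have more. Where it says the series, first, only, none or still open, it means among the compounds named here.

Measured compounds in this series:

compound 1 `CC(C)Nc1nc(NCc2ccco2)c2ccccc2n1`
compound 2 `CC(C)Nc1nc(NC2CCCCC2)c2ccccc2n1`
compound 3 `CC(C)Nc1nc(N(C)C)c2ccccc2n1`

For the measured compounds named here, in an ADME assay on J774.A1 cells (Mus musculus) for cytotoxicity, read by MTT assay, with a stated time of 72 h (on this read-out lower numbers stand for an effect already at smaller amounts and higher numbers for an effect only at larger amounts of compound), compound 1 gives 17000 nM, the only plain number among the three measured entries. Compound 2 stands at "not determined" (no result reported). For compound 3 the result is a limit of the assay, > 33000 nM. Going by the values given here, the one step between measured compounds, an at least 1.9-fold higher number from compound 1 to compound 3 (0.28 log units; that floor lies within the scatter), is therefore bounded by the limit of > 33000 nM in this assay, at which 1 of the 3 values shown sits, and its floor lies within the scatter, so it carries no direction of its own.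

Compound 4 `Cc1cccc2c(NCc3ccco3)nc(NC(C)C)nc12` differs from compound 1 by methyl in place of hydrogen on an aromatic carbon. Among the compounds with values here, no measured step touches the six-membered aromatic ring of carbon only; the single measured step replaces a group on a different aromatic carbon and is itself a floor inside the scatter. There is thus no measured evidence that bears on the methyl-for-hydrogen change, and the estimate rests on compound 1 alone, with 17000 nM as the anchor.

The expected step of no change at the digits printed from compound 1 to compound 4 (within the scatter) is therefore none beyond the scatter. Compound 4 is estimated at 17000 nM in this assay, with an expected range from 6000 nM to 45000 nM.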

Compound 4, half-maximal effective concentration: > 33000 nM
Compound 4: only a limit was reported (the forecaster's own chance of this, stated with the estimate: 25%); middle value at least 1.9-fold (0.28 log units) from the limit.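

For compound 4 the result in this assay is a limit of the assay, > 33000 nM, and not a number. For the compounds shown here, this is the first reading for a change on the six-membered aromatic ring of carbon only: methyl in place of hydrogen, ortho to a fused ring and meta to a fused ring, gives an at least 1.9-fold higher number from compound 1 to compound 4 (0.28 log units; that floor lies within the scatter), so the step carries no direction of its own and does not show that this position responds to the change. The size of the step stays unknown because the reading stops at the ceiling of the assay, which now also bounds a second compound in the series: the limit of > 33000 nM in this assay, at which 2 of the 4 values shown sit.

The compounds shown leave open whether methyl at this place moves the number at all, and how a chlorine atom, a methoxy group or an amine would read on the same aromatic carbon. Also open, as far as these compounds go, is whether any of these groups would give a plain number on another aromatic carbon of the same ring, with the ((furan-2-yl)methyl)amino group of compound 1 kept in place.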